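The source may hold more compounds than are shown below. What is called first, only, known or untested is meant among the compounds shown, and "the series" means these compounds.

Measured compounds:
Compound 1, `CC(C)n1ncc2c(C(=O)Nc3ccc(F)c(S(N)(=O)=O)c3)cc(-c3cccs3)nc21`, in an ADME assay on LLC-MK2 cells (Macaca mulatta) for cytotoxicity, read by spectrophotometry and crystal violet staining, with a stated time of 4 days (on this read-out lower numbers stand for higher toxicity in this test and higher numbers for lower toxicity in this test), gives 50000 nM.
Compound 2, `CC(C)n1ncc2c(C(=O)Nc3cccc(F)c3)cc(-c3cccs3)nc21`, in this assay gives > 200000 nM, which is a limit of the assay and not a number.
Compound 3, `CC(C)n1ncc2c(C(=O)N3CCc4cc(F)ccc43)cc(-c3cccs3)nc21`, in this assay gives > 200000 nM, likewise a limit.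

Going by the values given here, compound 2 therefore stands at the limit of > 200000 nM in this assay, at which 2 of the 3 values shown sit, and the value of compound 1 is the only number among the three. Among the compounds with values here, no step between measured compounds differing in one place is available. Compound 4, `CC(C)n1ncc2c(C(=O)Nc3ccccn3)cc(-c3cccs3)nc21`, differs from compound 2 by pyridin-2-yl in place of 3-fluorophenyl on an amide-type nitrogen. Since compound 2 sits at the limit of > 200000 nM in this assay, at which 2 of the 3 values shown sit, the expectation for compound 4 is that it stays at or near that limit, and the step of a number no higher from compound 2 to compound 4 (the limit leaves the size open) is estimated as none beyond the scatter. Compound 4 in this assay is expected around 200000 nM, between 80000 nM and 500000 nM, most likely reported only as a limit again.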

Compound 4, half-maximal cytotoxic concentration: > 200000 nM
Compound 4 ended at the assay's limit; the forecaster's own chance of this, stated with the estimate: 70%; the middle value lies on the limit itself.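

In this assay compound 4 gives > 200000 nM, a limit and not a number. Compound 2 gives > 200000 nM, also a limit, and no step can be read between compound 2 and compound 4. The compounds shown leave open whether pyridin-2-yl in place of 3-fluorophenyl on an amide-type nitrogen changes the half-maximal cytotoxic concentration at all.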